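An Ethoxycarbonyl Group Enters Where Hydroxy Stood

A few compounds are considered here, and "the series" means these few. Any claim that something is new, unique, unknown or untested is made for them only; others in the source may bear on it.

Compound 1, `CCc1c(F)c(N)c2c(=O)cc(-c3ccc(N)c(F)c3)oc2c1F`: in a functional assay on HeLa cells (Homo sapiens) for cytotoxicity, read by neutral red uptake, with a stated time of 3 days (a lower number here means a stronger inhibitor, a higher number a weaker inhibitor), compound 1 gives > 100000 nM, a limit of the assay.
Compound 2, `C[S+]([O-])c1c(F)c(N)c2c(=O)cc(-c3ccc(N)c(F)c3)oc2c1F`: in this assay compound 2 gives > 100000 nM, a limit of the assay.
Compound 3, `Nc1ccc(-c2cc(=O)c3c(N)c(F)c(O)c(F)c3o2)cc1F`: in this assay compound 3 gives > 100000 nM, a limit of the assay.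

Compound 3 therefore stands nowhere definite: its result is a limit, and the two further results that share its core are limits as well. The steps among the three measured compounds, a step that the two limits leave unreadable from compound 1 to compound 2, a step that the two limits leave unreadable from compound 1 to compound 3 and a step that the two limits leave unreadable from compound 2 to compound 3, cannot be read for size, because of the limit of > 100000 nM in this assay, at which 3 of the 3 values shown sit.

Compound 4, `CCOC(=O)c1c(F)c(N)c2c(=O)cc(-c3ccc(N)c(F)c3)oc2c1F`, is not yet measured. It differs from compound 3 by ethoxycarbonyl in place of hydroxy on an aromatic carbon. The measured steps that bear on this change are the three above, and none of them yields a readable size; all three results sit at the limit. No direction can be drawn from them. The expectation for compound 4 is therefore that it also reaches the limit, so that the step of a number no higher from compound 3 to compound 4 (the limit leaves the size open) is estimated to be none beyond the scatter. Compound 4 is expected to give 100000 nM in this assay, within a range from 30000 nM to 300000 nM, most likely reported only as a limit.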

Compound 4, half-maximal inhibitory concentration: > 100000 nM
Compound 4: no number, only a limit (the forecaster's own chance of this, stated with the estimate: 85%); the middle value sits exactly at the limit.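

In this assay compound 4 gives > 100000 nM, a limit of the assay. No step from compound 4 to compound 1, compound 2 or compound 3 can be read for size, because all four results end at the same limit: the limit of > 100000 nM in this assay, at which 4 of the 4 values shown sit.

The compounds shown leave open whether the group on this aromatic carbon alters the result in this assay at all.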